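The source may report more compounds than this note shows. Statements on the series, on what has been measured and on what is new or still open speak of the compounds shown alone.

Series notes, bioavailability. The series shares one core; compound 1 is `Cc1ccc(CNC(=O)Nc2ccc(Oc3ncnc4cc(N(C)C)ccc34)cc2)cn1` and compound 2 is `CN(C)c1ccc2c(Oc3ccc(NC(=O)NCc4ccc(F)cc4)cc3)ncnc2c1`. In an ADME assay on the whole organism (Rattus norvegicus, strain Sprague-Dawley) for pharmacokinetics, read by LC-MS, with a stated time of 24 h (a lower number here means that a smaller share of the oral dose reaches the circulation, a higher number that a larger share of the oral dose reaches the circulation), compound 1 gives 10.4%. In this assay, among the measured compounds shown here, compound 2 gives 7.3%, the lower of the two numbers so far, with compound 1 as its only neighbour; the one measured step reads a number 3.1 percentage points lower from compound 1 to compound 2 (within the scatter), so the two values are not told apart.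

The next compound, compound 3, is `COc1ccc(CNC(=O)Nc2ccc(Oc3ncnc4cc(N(C)C)ccc34)cc2)cn1`. It differs from compound 2 in one place: 6-methoxypyridin-3-yl in place of 4-fluorophenyl on a saturated chain carbon bound to an amide-type nitrogen. For the measured compounds named here, the only measured step that bears on this position is the one from compound 1 to compound 2, which exchanged a six-membered aromatic ring with one hetero atom for a carbon-only ring at the same saturated chain carbon and stayed within the scatter. The change to compound 3 goes back the other way, to a ring with one hetero atom carrying a methoxy group in place of a methyl group. On that basis no step beyond the scatter is expected; the step from compound 2 to compound 3 in this assay is estimated as a number 2.7 percentage points higher from compound 2 to compound 3 (within the scatter). For compound 3 in this assay the expected value is 10%, between 4% and 20%.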

Compound 3, oral bioavailability: 30.7%
Compound 3: the middle estimate sits 20.7 percentage points below what was measured, outside the stated range (above it).
By their numbers in this assay, from the lowest: compounds 2 and 1 (each within the scatter of the next); then compound 3.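

In this assay, the group on the saturated chain carbon bound to an amide-type nitrogen does matter, which the earlier pair could not show: the series reads a number 23.4 percentage points higher from compound 2 to compound 3 (beyond the scatter) for the exchange of 4-fluorophenyl for 6-methoxypyridin-3-yl. The ring with one hetero atom is not enough on its own, since the step reads a number 3.1 percentage points lower from compound 1 to compound 2 (within the scatter) when 6-methylpyridin-3-yl gives way to 4-fluorophenyl, whereas methoxy in place of methyl on an aromatic carbon reads a number 20.3 percentage points higher from compound 1 to compound 3 (beyond the scatter) with the rest of the structure unchanged. On these three compounds, the higher number appears only with the methoxy group on the ring with one hetero atom, and nothing at hand explains that result.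

The compounds shown do not separate the contribution of the methoxy group from that of the ring it sits on, and 4-methoxyphenyl at the same saturated chain carbon would make that comparison directly. They also leave open how narrowly the gain depends on methoxy itself, as an ethoxy group or a dimethylamino group in its place would show.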